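A Second Bromine on a Weak Benzophenone

The compounds below may be only part of what the source reports. "The series", "measured", "known", "first", "only" and "open" are said of these compounds alone.

Compound 2 `O=C(c1ccccc1)c1cc(O)c(O)cc1Br` gives 84000 nM in a functional assay, read by MTT assay, with a stated time of 4 h; on this read-out higher numbers stand for weaker inhibition and lower numbers for stronger inhibition. Going by the values given here, its number is the lowest of the two measured so far, but the gap to compound 1 `O=C(c1ccc(O)c(O)c1)c1c(Cl)c(O)c(O)c(O)c1Cl`, which gives 87300 nM in this assay, lies within the scatter, so the two cannot be told apart. Compound 3 `O=C(c1ccccc1)c1cc(O)c(O)c(Br)c1Br` differs from compound 2 by bromo in place of hydrogen on an aromatic carbon. Among the compounds with values here, no measured pair shows the effect of such a change, so no step beyond the scatter is expected in this assay. Compound 3 is estimated at 65000 nM, with a range from 20000 nM to 200000 nM. This corresponds to an expected step of a 1.3-fold lower number from compound 2 to compound 3 (0.11 log units; within the scatter).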

Compound 3, half-maximal inhibitory concentration: 87700 nM
Estimate against measurement, compound 3: 1.3-fold (0.13 log units) below; the range from low to high includes it.
By their numbers in this assay, from the lowest: compounds 2, 1 and 3 (each within the scatter of the next).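

In this assay, placing bromo on this aromatic carbon, ortho to a bromo group and ortho to a hydroxy group, gives a 1.0-fold higher number from compound 2 to compound 3 (0.02 log units; within the scatter), so compound 2 and compound 3 cannot be told apart. Going by these compounds alone, this is the first pair here that differs in only one place, and it shows that a second bromine at this position brings no readable step in this assay. Nothing available explains this result. As far as these compounds go, whether an amine or a carboxylic acid at this position would give a step beyond the scatter remains open.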